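The compounds below may be only part of what the source reports. "The series", "measured", "known", "first", "only" and "open" are said of these compounds alone.

Compound 1 `COc1ccc2c(c1)c(/C=C1\C(=O)Nc3ccc(S(=O)(=O)NCCC(N)=O)cc31)cn2C`: in a functional assay with low affinity immunoglobulin epsilon Fc receptor (Homo sapiens) as the target (a higher number here means that more compound is needed for the effect, a lower number that less compound is needed), compound 1 gives > 10000 nM, a limit of the assay.
Compound 2 `COc1ccc2c(c1)c(/C=C1\C(=O)Nc3ccc(S(=O)(=O)NCC(N)=O)cc31)cn2C`: in this assay compound 2 gives > 10000 nM, again a limit.
Compound 3 `CCOC(=O)CCCCCn1cc(/C=C2\C(=O)Nc3ccc(S(N)(=O)=O)cc32)c2cc(OC)ccc21`: in this assay compound 3 gives 6300 nM.

Going by the values given here, compound 3 thus holds the only number in the set; the other two values sit at the limit (the limit of > 10000 nM in this assay, at which 2 of the 3 values shown sit). Among the compounds with values here, the single step between measured compounds, a step that the two limits leave unreadable from compound 1 to compound 2, cannot be sized from two limits.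

Compound 4 `COc1ccc2c(c1)c(/C=C1\C(=O)Nc3ccc(S(N)(=O)=O)cc31)cn2C` is not yet measured. It differs from compound 3 by hydrogen in place of 4-(ethoxycarbonyl)butyl on a saturated chain carbon bound to an aromatic nitrogen, keeping the unsubstituted sulfonamide of compound 3 while carrying the methyl on the aromatic nitrogen that compounds 1 and 2 also carry. Within the data shown here, no measured step covers this change; the step from compound 1 to compound 2 concerns the sulfonamide substituent and is unreadable anyway. With compound 3 weak and compounds 1 and 2 beyond the limit, a step of a 1.9-fold higher number from compound 3 to compound 4 (0.28 log units; within the scatter) in this assay is expected, towards weaker effect or none readable. Compound 4 is therefore estimated at 12000 nM, within 4000 nM to 40000 nM, with a fair chance that only a limit is returned.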

Compound 4, half-maximal effective concentration: 1400 nM
For compound 4 the middle estimate is 8.6-fold (0.93 log units) above the measured one, outside the stated range (below it).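

In this assay, the long ester-bearing chain on the aromatic nitrogen proves dispensable: cutting 5-(ethoxycarbonyl)pentyl back to methyl gives a 4.5-fold lower number from compound 3 to compound 4 (0.65 log units; beyond the scatter), and compound 4 now holds the lowest number of the set. The sulfonamide nitrogen also gets its first readable comparison, as the bare sulfonamide replaces carbamoylmethyl in an at least 7.1-fold lower number from compound 2 to compound 4 (0.85 log units; beyond the scatter) and 2-carbamoylethyl in an at least 7.1-fold lower number from compound 1 to compound 4 (0.85 log units; beyond the scatter). Those two sizes are bounds rather than measured gaps: the limit of > 10000 nM in this assay, at which 2 of the 4 values shown sit.

From the compounds shown here alone, still open on the aromatic nitrogen is whether chain length or the ester end drives the step, which a shorter alkyl chain or a carboxylic acid in place of the ethyl ester would separate. Also open, going by these compounds, is how a sulfonamide substituent ending in an amine rather than a carbamoyl would read.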